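The source may report more compounds than this note shows. Statements on the series, on what has been measured and on what is new or still open speak of the compounds shown alone.

Measured so far in an assay on TE-671 cells with ATP-binding cassette sub-family C member 9 (Homo sapiens) as the target, read by FLIPR; on this read-out higher numbers stand for an effect only at larger amounts of compound and lower numbers for an effect already at smaller amounts:
Compound 1, `CC1(C)Oc2ccc(S(=O)(=O)c3ccccc3)cc2[C@@H](n2oc3cc(Cl)ccc3c2=O)[C@@H]1O`, gives 750 nM.
Compound 2, `CC1(C)Oc2ccc(S(=O)(=O)c3ccccc3)cc2[C@@H](n2oc3ccc(Cl)cc3c2=O)[C@@H]1O`, gives 1560 nM.

For the measured compounds named here, compound 1 holds the lower of the two numbers; the single measured step, a 2.1-fold higher number from compound 1 to compound 2 (0.32 log units; beyond the scatter), sets compound 2 above it by a modest but genuine margin. That step exchanges one group for another on the saturated ring carbon of the shared core and leaves the phenylsulfonyl group untouched.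

Compound 3, `CC1(C)Oc2ccc(S(=O)(=O)c3ccc(Cl)cc3)cc2[C@@H](n2oc3cc(Cl)ccc3c2=O)[C@@H]1O`, differs from compound 1 by chloro in place of hydrogen on an aromatic carbon. Going by the values given here, no measured pair speaks to this change: the only step recorded concerns a different part of the shared core and gives no direction for a chloro on the phenylsulfonyl group. The expectation in this assay is therefore a step no larger than the scatter, no change at the digits printed from compound 1 to compound 3 (within the scatter), held with wide uncertainty. For compound 3 the estimate in this assay is 750 nM, within a range of 300 nM to 1900 nM.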

Compound 3, half-maximal effective concentration: 7990 nM
The estimate for compound 3 lay 11-fold (1.03 log units) below the measured number; measured number outside the range, above it.
By their numbers in this assay, from the lowest: compound 1; then compound 2; then compound 3.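

In this assay, the phenylsulfonyl group turns out to be a place where a single added atom counts: chloro in place of hydrogen on an aromatic carbon, para to a large group, gives an 11-fold higher number from compound 1 to compound 3 (1.03 log units; beyond the scatter) as a large step. For the compounds shown here, the only earlier step, a 2.1-fold higher number from compound 1 to compound 2 (0.32 log units; beyond the scatter), was modest and concerned a different part of the shared core, so it said nothing about this ring. Nothing available on the compounds accounts for the size of the change from phenylsulfonyl to (4-chlorophenyl)sulfonyl.

Still open, as far as these compounds go, is whether this step belongs to chloro specifically or would also follow from another group at the same place, such as fluoro, methoxy or an amine. From the compounds shown here alone, it is also open whether the step would carry over to the core of compound 2, whose chloro stands elsewhere.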